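The compounds below may be only part of what the source reports. "The series", "measured", "known", "first", "only" and "open" are said of these compounds alone.

Among the compounds with values here, both compounds measured so far share one core, a ring that carries a hydroxamic acid side chain and an amide-type nitrogen bearing a chain that ends in a benzene ring. Compound 1, `O=C(CCC1=CCN(CCCc2ccc(Br)cc2)C1=O)NO`, carries a three-carbon chain ending in a 4-bromophenyl group; compound 2, `Cc1cccc(CN2CC=C(CCC(=O)NO)C2=O)c1`, carries a one-carbon chain ending in a 3-methylphenyl group. In a functional assay on NCI-H23 cells (Homo sapiens) for inhibition, read by sulforhodamine B assay (on this read-out lower numbers stand for stronger inhibition of growth and higher numbers for weaker inhibition of growth), compound 1 gives 2520 nM, the higher of the two numbers; in this assay compound 2 gives 2500 nM, and the gap between the two lies within the scatter of repeated measurements, so neither can be called stronger.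

Compound 3, `Cc1cccc(CCCN2CC=C(CCC(=O)NO)C2=O)c1`, keeps the three-carbon chain of compound 1 and differs from it in one place: 3-methylphenyl in place of 4-bromophenyl on a saturated chain carbon, three bonds along the chain from an amide-type nitrogen in a ring. Within the data shown here, no measured pair shows the effect of this exchange on its own. Since compound 2, which carries the same 3-methylphenyl group on a shorter chain, sits within the scatter of compound 1, no step beyond the scatter is expected, and the step of a 1.0-fold lower number from compound 1 to compound 3 (0.00 log units; within the scatter) is estimated as essentially flat. In this assay compound 3 is therefore expected to give about 2500 nM, with a plausible range from 1000 nM to 6000 nM.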

Compound 3, concentration for 50% growth inhibition: 2520 nM
Beside the measured number, compound 3's estimate is 1.0-fold (0.00 log units) below it, and the stated range covers the measured number.
By their numbers in this assay, from the lowest: compounds 2, 1 and 3 (each within the scatter of the next).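

Within the data shown here, this exchange gives the first direct reading at this position: in this assay, 3-methylphenyl in place of 4-bromophenyl gives no change at the digits printed from compound 1 to compound 3 (within the scatter), so on the three-carbon chain this read-out does not tell the two groups apart. The 3-methylphenyl group also allows a reading of chain length that the first two compounds could not give, since they differed in both chain and ring group: compound 2, with the one-carbon chain, gives 2500 nM, and compound 3, with the three-carbon chain, gives 2520 nM, two values within the scatter of each other. No independent evidence accounts for this flat picture.

The exchange changes both the group on the benzene ring and its numbered place, so the compounds shown cannot separate these two changes, and an unsubstituted phenyl group or 3-bromophenyl would be needed to do so. As far as these compounds go, it also remains open whether a more different group on the ring, such as an amine or a carboxylic acid, or a longer chain would move the number beyond the scatter.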